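Vero cell tolerance notes on one amide series

The source may hold more compounds than are shown below. What is called first, only, known or untested is meant among the compounds shown, and "the series" means these compounds.

Compound 1 `CC1=C(C(=O)Nc2ccc(F)cc2)C(c2ccccc2)NC(=O)N1`: in an ADME assay on Vero cells (Chlorocebus sabaeus) for cytotoxicity, read by XTT assay, with a stated time of 72 h (a higher number here means that more compound is tolerated, a lower number that less compound is tolerated), compound 1 gives > 100000 nM, which is a limit of the assay.
Compound 2 `CC1=C(C(=O)NC2CCCCC2)C(c2ccccc2)NC(=O)N1`: in this assay compound 2 gives > 100000 nM, which is a limit of the assay.
Compound 3 `CC1=C(C(=O)Nc2ccccc2Cl)C(c2ccc(Cl)cc2)NC(=O)N1`: in this assay compound 3 is recorded only as "non-toxic" (no number reported), with no number attached.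

Among the measured compounds shown here, compound 3 therefore stands without a numerical value, and the two other results in this assay are limits, so no measured compound carries a number that could anchor it. For the measured compounds named here, the single one-place step, a step that the two limits leave unreadable from compound 1 to compound 2, cannot be sized because both of its ends sit at the limit of > 100000 nM in this assay, at which 2 of the 3 values shown sit.

Compound 4 `CC1=C(C(=O)Nc2ccccc2Cl)C(c2cccc([N+](=O)[O-])c2)NC(=O)N1` differs from compound 3 by 3-nitrophenyl in place of 4-chlorophenyl on a saturated ring carbon. Going by the values given here, no measured step touches this change: the only step in hand concerns the amide-type nitrogen, not the saturated ring carbon, and it is itself unreadable. Among the compounds with values here, the expectation for this assay can rest only on the fact that every result so far is either a limit or a plain report of no toxicity, so no step beyond the scatter in either direction is expected. Compound 4 is accordingly expected to give 150000 nM, in the range 50000 nM to 500000 nM, most probably reported again as a limit rather than a number.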

Compound 4, half-maximal cytotoxic concentration: "non-toxic" (no number reported)
Nothing numeric was reported for compound 4, so the estimate cannot be set against anything.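

In this assay, compound 3 and compound 4 are both recorded only as "non-toxic", without a number, so no step can be read between them. Still open is whether 3-nitrophenyl in place of 4-chlorophenyl changes tolerance at all, and how any of the four compounds compares with the others, because the remaining results sit at a limit: the limit of > 100000 nM in this assay, at which 2 of the 4 values shown sit.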